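Dropping the ethyl from the piperidine ring of compound 2

The compounds below may be only part of what the source reports. "The series", "measured", "known", "first", "only" and "open" are said of these compounds alone.

Measured compounds:
compound 1, `CC(C)CC1CCCN1C[C@@H](O)CNS(=O)(=O)c1cccc2ccccc12`: 2510 nM; 6310 nM (2 entries)
compound 2, `CC[C@H]1CCCCN1C[C@@H](O)CNS(=O)(=O)c1cccc2ccccc12`: 100 nM

Two compounds share a core in which a naphthalene sulfonamide is joined through a hydroxypropyl chain to a saturated nitrogen ring. In an assay on HEK293 cells for inhibition of sodium- and chloride-dependent glycine transporter 1 (Homo sapiens) (a higher number here means a weaker inhibitor, a lower number a stronger inhibitor), compound 1 gives 2510 nM; 6310 nM (2 entries), and the several entries of compound 1 in this assay, 2510 nM; 6310 nM (2 entries) shows its entries spread across a range. In this assay, among the compounds with values here, compound 2 gives 100 nM, the only single number recorded for it; a further entry for compound 2 reports no single number. Placed side by side, the number for compound 2 is well below both entries for compound 1, though no direct comparison between these two is made here, since they differ in more than one place.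

Compound 3, `O=S(=O)(NC[C@H](O)CN1CCCCC1)c1cccc2ccccc12`, has not yet been measured. It differs from compound 2 by hydrogen in place of ethyl on a saturated ring carbon; cut one bond further out, 2-ethylpiperidin-1-yl becomes piperidin-1-yl. Within the data shown here, no measured pair in this set isolates such a change, so the direction must be estimated from the structures alone. The expectation is that compound 3 will be a weaker inhibitor than compound 2, with a step of an 8.0-fold higher number from compound 2 to compound 3 (0.90 log units; beyond the scatter) beyond the scatter. For compound 3 the estimated value in this assay is 800 nM, in a range from 200 nM to 4000 nM.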

Compound 3, half-maximal inhibitory concentration: 3160 nM
Compound 3: the middle estimate sits 4.0-fold (0.60 log units) below what was measured; measured number inside the range.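

Within the data shown here, this is the first pair in the set that differs in one place only, so it gives the first direct reading of what the ethyl on this saturated ring carbon, next to the ring nitrogen, contributes. In this assay, replacing 2-ethylpiperidin-1-yl with piperidin-1-yl gives a 32-fold higher number from compound 2 to compound 3 (1.50 log units; beyond the scatter), which shows that a group of only 2 heavy atoms, with no ring and no hydrogen-bond donors or acceptors, accounts for a large part of the inhibition seen with compound 2, and that the unsubstituted piperidin-1-yl does not keep it. The compounds shown establish the size of this step but offer no measurement that explains it.

Going by these compounds, it remains open how the number would respond to a methyl or a longer chain, such as propyl, on the same ring carbon, and so whether ethyl is close to the best size there. It is also unknown whether a hydroxyl or an amine at this place could stand in for the ethyl, or whether the step would be similar with the ethyl on the opposite face of the ring.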